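The source may hold more compounds than are shown below. What is called first, only, known or untested is meant among the compounds shown, and "the series" means these compounds.

Working notes on the coumarin-bearing pyrazoline series, read in a functional assay on PC-3 cells (Homo sapiens) for cytotoxicity, read by MTT assay, with a stated time of 48 h; on this read-out lower numbers stand for stronger inhibition and higher numbers for weaker inhibition.

Compound 1 `CCC(=O)N1N=C(c2cc3ccccc3oc2=O)CC1c1ccccc1` gives 4370 nM. Compound 2 `CCCNCC(=O)N1N=C(c2cc3ccccc3oc2=O)CC1c1ccccc1` gives 7270 nM, and the step of a 1.7-fold higher number from compound 1 to compound 2 (0.22 log units; within the scatter) stays within the scatter. Compound 3 `O=C(CNC1CCCCC1)N1N=C(c2cc3ccccc3oc2=O)CC1c1ccccc1` gives 48500 nM, the highest number of the three measured: the step of an 11-fold higher number from compound 1 to compound 3 (1.05 log units; beyond the scatter) and the step of a 6.7-fold higher number from compound 2 to compound 3 (0.82 log units; beyond the scatter) are both beyond the scatter, so on the numbers shown compound 3 is the weakest of the measured set in this assay.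

Compound 4 `CC1CCCN(CC(=O)N2N=C(c3cc4ccccc4oc3=O)CC2c2ccccc2)C1` is not yet measured. It differs from compound 3 by 3-methylpiperidin-1-yl in place of cyclohexylamino on a saturated chain carbon bound to a carbonyl carbon. Going by the values given here, no measured step covers a closure of the amine into a ring or the loss of the amine hydrogen, so the bearing of the measured steps is indirect. The step of a 6.7-fold higher number from compound 2 to compound 3 (0.82 log units; beyond the scatter) shows that a change at the amine nitrogen can move the number by a modest amount, and the step of an 11-fold higher number from compound 1 to compound 3 (1.05 log units; beyond the scatter) sets the span so far. The expected step of a 1.9-fold lower number from compound 3 to compound 4 (0.29 log units; within the scatter) is therefore small, without a confident direction, and the estimate for compound 4 is 25000 nM, within the range 7000 nM to 80000 nM.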

Compound 4, half-maximal inhibitory concentration: 28300 nM
For compound 4 the middle estimate is 1.1-fold (0.05 log units) below the measured one; the measured number falls inside the stated range.
By their numbers in this assay, from the lowest: compounds 1 and 2 (each within the scatter of the next); then compounds 4 and 3 (each within the scatter of the next).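

In this assay, the step of a 1.7-fold lower number from compound 3 to compound 4 (0.23 log units; within the scatter) stays within the scatter. On a saturated chain carbon bound to a carbonyl carbon, 3-methylpiperidin-1-yl and cyclohexylamino are therefore not told apart, and losing the amine hydrogen-bond donor while changing how the ring is attached does not register on this read-out. The steps of a 3.9-fold higher number from compound 2 to compound 4 (0.59 log units; beyond the scatter) and a 6.5-fold higher number from compound 1 to compound 4 (0.81 log units; beyond the scatter) are both beyond the scatter, so compound 4 joins compound 3 in sitting apart from compounds 1 and 2, with a six-membered ring at this position going with the higher numbers in this small set, and no evidence is available to explain this.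

On these data alone, the contribution of the ring methyl remains open, as does the separate role of the ring and the amine hydrogen. Piperidin-1-yl without the methyl, morpholin-4-yl or open-chain diethylamino would help separate these.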